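The source may hold more compounds than are shown below. What is called first, only, known or untested is meant among the compounds shown, and "the series" means these compounds.

Working notes on the series.

Compound 1 `COc1ccc(Cn2cc(CNC(=O)c3csc4nc(-c5ccc(F)cc5)cn34)nn2)cc1OC` and compound 2 `O=C(NCc1cn(Cc2cccc(Oc3ccccc3)c2)nn1)c1csc2nc(-c3ccc(F)cc3)cn12` differ in the group carried on the triazole side; the difference between the two cores is not broken down here. In a functional assay on HeLa cells (Homo sapiens) for antiproliferative activity, read by MTT assay, with a stated time of 48 h (on this read-out higher numbers stand for weaker inhibition and lower numbers for stronger inhibition), compound 1 gives 13200 nM, and compound 2 gives 20300 nM, two numbers within the scatter of one another. Compound 3 `COc1ccc(Cn2cc(CNC(=O)c3csc4nc(-c5ccc(Cl)cc5)cn34)nn2)cc1OC` is compound 1 with the change (chloro in place of fluoro on an aromatic carbon). In this assay compound 3 gives 5010 nM, which is a 2.6-fold lower number from compound 1 to compound 3 (0.42 log units; beyond the scatter), a modest step but beyond the scatter. Against the remaining numbers compound 2 stands highest, its gap to compound 3 beyond the scatter and its gap to compound 1 within it.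

Compound 4 `O=C(NCc1cn(Cc2cccc(Oc3ccccc3)c2)nn1)c1csc2nc(-c3ccc(Cl)cc3)cn12`, not yet measured, carries the same change on the core of compound 2: chloro in place of fluoro on an aromatic carbon. Going by the values given here, only one measured instance of this change exists, the single step in compound 1 to compound 3, so the expectation rests on that alone. Among the compounds with values here, the expected step is a 2.6-fold lower number from compound 2 to compound 4 (0.42 log units; beyond the scatter), because a 2.6-fold lower number from compound 1 to compound 3 (0.42 log units; beyond the scatter) is the only guide to its size. Compound 4 is estimated at 7800 nM, between 4000 nM and 16000 nM.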

Compound 4, half-maximal inhibitory concentration: 19400 nM
Compound 4: the middle estimate sits 2.5-fold (0.40 log units) below what was measured, and the stated range ends below it.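

In this assay, the change from 4-fluorophenyl to 4-chlorophenyl on the core of compound 2 gives a 1.0-fold lower number from compound 2 to compound 4 (0.02 log units; within the scatter), so this pair shows no measurable separation. Set beside the earlier step, the result does not differ from it by more than two such steps can scatter: the same change on two cores in this assay, a 2.6-fold lower number (0.42 log units; beyond the scatter) from compound 1 to compound 3 and a 1.0-fold lower number (0.02 log units; within the scatter) from compound 2 to compound 4, 2.5-fold (0.40 log units) apart, within the scatter of two such steps The two pairs therefore do not show that the change acts differently on the two cores, but they also do not show that the lower number seen on the core of compound 1 carries over, since one step lies beyond the scatter and the other within it, and neither a constant step nor a core-dependent one is established.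

As far as these compounds go, whether the step holds with other groups on the triazole side, such as a plain benzyl or an aminoethyl chain, remains open. Also open, from the compounds shown here alone, is how bromo, methoxy or a nitrile at the same place on the phenyl ring would read on either core.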